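The compounds below may be only part of what the source reports. "The series", "measured", "known", "first", "only" and "open" are said of these compounds alone.

Working notes on the series, read in an ADME assay on L1210/0 cells (Mus musculus) for cytotoxicity, with a stated time of 48 h; a lower number here means a stronger inhibitor, a higher number a weaker inhibitor. Compound 1 (`Oc1ncnc2c1ncn2C[C@@H]1C[C@H](O)c2ccccc21`) gives > 200000 nM, which is a limit and not a number. Compound 2 (`COc1ncnc2c1ncn2C[C@@H]1C[C@H](CO)c2ccccc21`) gives > 200000 nM, also a limit, so it stands with compound 1 at the end of the range: the limit of > 200000 nM in this assay, at which 2 of the 2 values shown sit. Compound 3 (`OC[C@H]1C[C@@H](Cn2cnc3c(O)ncnc32)c2ccccc21`) has hydrogen in place of methyl on an oxygen on an aromatic ring of compound 2, that is methoxy to hydroxy: hydrogen in place of methyl on an oxygen on an aromatic ring. Compound 1 already carries hydroxy and gives the limit > 200000 nM. In this assay the expected step is a number no higher from compound 2 to compound 3 (the limit leaves the size open), none beyond the scatter. For compound 3 the estimate is 200000 nM, expected within 100000 nM to 400000 nM.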

Compound 3, half-maximal inhibitory concentration: > 200000 nM
Compound 3 gave a limit, no number (the forecaster's own chance of this, stated with the estimate: 85%); the middle value sits exactly at the limit.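

Compound 3 also gives only a limit, so no step can be read to it from compound 1 or compound 2: the limit of > 200000 nM in this assay, at which 3 of the 3 values shown sit.

The compounds shown leave open what size, if any, the change from methoxy to hydroxy has in this assay.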